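Branched ester to simple ether on the side-chain oxygen

This account rests on a few compounds, and the source may have more. Where it says the series, first, only, none or still open, it means among the compounds named here.

Compound 3 `CC(C)=CC[C@@H](OC(=O)CC(C)(O)C(C)C)C1=CC(=O)c2c(O)ccc(O)c2C1=O` gives 16900 nM in a functional assay on DU-145 cells (Homo sapiens) for cytotoxicity, read by MTT assay (on this read-out lower numbers stand for stronger inhibition and higher numbers for weaker inhibition), the lowest of the two numbers available. Compound 2 `CCCC(C)(O)CC(=O)O[C@H](CC=C(C)C)C1=CC(=O)c2c(O)ccc(O)c2C1=O` gives 75000 nM, so that a 4.4-fold lower number from compound 2 to compound 3 (0.65 log units; beyond the scatter). Compound 1 `CC(C)=CC[C@@H](OC(=O)c1ccco1)C1=CC(=O)c2c(O)ccc(O)c2C1=O` reaches only the assay limit (the limit of > 100000 nM in this assay, at which 1 of the 3 values shown sits), reported as > 100000 nM. The step to compound 4 `CCC(O)CO[C@H](CC=C(C)C)C1=CC(=O)c2c(O)ccc(O)c2C1=O` is 2-hydroxybutyl in place of (2-hydroxy-2,3-dimethylbutyl)carbonyl on an oxygen on a saturated carbon. The measured steps bear on it directly: an at least 5.9-fold lower number from compound 1 to compound 3 (0.77 log units; beyond the scatter) shows the whole acyl group carried the gain, and a 4.4-fold lower number from compound 2 to compound 3 (0.65 log units; beyond the scatter) shows that the branch at the carbinol carbon alone mattered. Compound 4 removes the carbonyl and both methyl branches at once, so the number is expected to climb back toward that of compound 2 or beyond. Compound 4 is therefore estimated at 55000 nM, ranging 17000 nM to 150000 nM, meaning a 3.3-fold higher number from compound 3 to compound 4 (0.51 log units; beyond the scatter).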

Compound 4, half-maximal inhibitory concentration: 16400 nM
The estimate for compound 4 lay 3.4-fold (0.53 log units) above the measured number; measured number below the stated range.
By their numbers in this assay, from the lowest: compounds 4 and 3 (each within the scatter of the next); then compound 2. At a limit, above all of these: compound 1.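

Compound 4 shows that the carbonyl and the branched acyl chain are not required at this oxygen on a saturated carbon: the simple 2-hydroxybutyl ether and the ester do not separate, with a 1.0-fold lower number from compound 3 to compound 4 (0.01 log units; within the scatter). The ether also holds a clear margin over the other hydroxylated ester, with a 4.6-fold lower number from compound 2 to compound 4 (0.66 log units; beyond the scatter). Against the furan-2-yl ester, which sits at an assay limit, the step is only a floor: an at least 6.0-fold lower number from compound 1 to compound 4 (0.78 log units; beyond the scatter).

From the compounds shown here alone, it remains open whether the hydroxyl of the 2-hydroxybutyl chain is needed, and how an amine in its place or a longer ether chain would read.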